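The source may report more compounds than this note shows. Statements on the series, on what has been measured and on what is new or still open speak of the compounds shown alone.

Three compounds have been measured in a functional assay on PC-3 cells (Homo sapiens) for antiproliferative activity, read by MTT assay, with a stated time of 48 h; on this read-out higher numbers stand for weaker inhibition and lower numbers for stronger inhibition:

Compound 1 `C=C(/C=C/c1ccc(OC)c(N)c1)c1cc(OC)c(OC)c(OC)c1` gives 560 nM
Compound 2 `C=C(/C(C)=C/c1ccc(OC)c(O)c1)c1cc(OC)c(OC)c(OC)c1` gives 61 nM
Compound 3 `CC=C(/C(C)=C/c1ccc(OC)c(O)c1)c1cc(OC)c(OC)c(OC)c1` gives 789 nM

Compound 3 and compound 1 give numbers that lie within the usual scatter of each other, whereas compound 2 sits well apart from both. For the measured compounds named here, the one step that bears on the present question is a 13-fold higher number from compound 2 to compound 3 (1.11 log units; beyond the scatter), a large loss that came from a single added carbon on the chain.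

Compound 4 `CCC=C(/C(C)=C/c1ccc(OC)c(O)c1)c1cc(OC)c(OC)c(OC)c1` carries the change (methyl in place of hydrogen on a saturated chain carbon bound to a double-bonded chain carbon); cut one bond further out, this is methyl to ethyl on the same chain. Going by the values given here, no measured pair shows this exact extension, so the expectation rests on the direction already seen: the first lengthening of the chain cost a good deal, and a second lengthening is not expected to recover it. The estimate is a further modest rise in this assay , a 1.9-fold higher number from compound 3 to compound 4 (0.28 log units; within the scatter), with wide uncertainty because only compound 3 with 789 nM anchors it. Compound 4 is therefore expected to give about 1500 nM, within a range from 500 nM to 5000 nM.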

Compound 4, half-maximal inhibitory concentration: 4230 nM
Compound 4: middle estimate off by 2.8-fold (0.45 log units), on the low side; the range from low to high includes it.
By their numbers in this assay, from the lowest: compound 2; then compounds 1 and 3 (each within the scatter of the next); then compound 4.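

In this assay, the loss did not level off after the first added carbon (a 13-fold higher number from compound 2 to compound 3 (1.11 log units; beyond the scatter)) but continued when methyl became ethyl on the same chain (a 5.4-fold higher number from compound 3 to compound 4 (0.73 log units; beyond the scatter)). Taken as a whole, ethyl in place of hydrogen on this double-bonded chain carbon gives a far larger change (a 69-fold higher number from compound 2 to compound 4 (1.84 log units; beyond the scatter)), so across compound 2, compound 3 and compound 4 the number rises with each step, and each step lies beyond the scatter. Nothing given here explains this trend.

The compounds shown leave open whether a longer chain such as propyl would raise the number further, or whether a branched group such as isopropyl would follow ethyl. They also leave open how a hydroxyl at the end of this chain would read in this assay.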